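This account rests on a few compounds, and the source may have more. Where it says the series, first, only, none or still open, it means among the compounds named here.

Measured in a functional assay on PC-3 cells (Homo sapiens) for cytotoxicity, read by MTT assay, with a stated time of 48 h; on this read-out higher numbers stand for weaker inhibition and lower numbers for stronger inhibition: compound 1 `CC(=O)Oc1ccccc1C1CC(C)=NN1C(=O)CN(C(C)C)C(C)C` gives 24500 nM; compound 2 `CNCC(=O)N1N=C(c2cc3ccccc3oc2=O)CC1c1ccccc1` gives 2300 nM.

Compound 2 holds the lowest of these two numbers, and compound 1 stands at a higher number, a gap beyond the scatter. Compound 3 `O=C(CN1CCCC1)N1N=C(c2cc3ccccc3oc2=O)CC1c1ccccc1` differs from compound 2 by pyrrolidin-1-yl in place of methylamino on a saturated chain carbon bound to a carbonyl carbon. Among the compounds with values here, no measured pair shows this change on its own, and compound 1 differs from compound 2 at several places, so its value gives no step to lean on. The step of a 1.1-fold higher number from compound 2 to compound 3 (0.04 log units; within the scatter) is expected to stay within the scatter. Compound 3 is therefore estimated at 2500 nM, with a range from 900 nM to 8000 nM.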

Compound 3, half-maximal inhibitory concentration: 50200 nM
Compound 3: middle estimate off by 20-fold (1.30 log units), on the low side, and the stated range ends below it.
By their numbers in this assay, from the lowest: compound 2; then compound 1; then compound 3.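

The position on the saturated chain carbon bound to a carbonyl carbon proves sensitive in this assay: pyrrolidin-1-yl in place of methylamino gives a 22-fold higher number from compound 2 to compound 3 (1.34 log units; beyond the scatter) on this single change. The change removes the hydrogen-bond donor of methylamino and adds a five-membered non-aromatic ring, and this one pair cannot separate the two. No available evidence bears on the reason for the step. On these data alone, whether a dimethylamino or an ethylamino group would read close to compound 2 or to compound 3 remains open.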